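A Third Methoxy Group Enters Compound 1

The source may hold more compounds than are shown below. What is called first, only, known or untested is meant among the compounds shown, and "the series" means these compounds.

Among the measured compounds shown here, compound 1 `COc1ccc(C(=O)/C=C/c2cc(-c3cc(OC)c(OC)c(OC)c3)n[nH]2)cc1OC` gives 72% in a functional assay on RXF 393 cells (Homo sapiens) for cytotoxicity, read by sulforhodamine B assay, with a stated time of 48 h, tested at 1 uM (a higher number here means a weaker effect of the compound at the concentration tested, a lower number a stronger effect), the higher of only two numbers measured, with compound 2 `COc1ccc(C(=O)/C=C/c2cc(-c3cc(OC)c(OC)c(OC)c3)n[nH]2)cc1` nearest at 67%. For the measured compounds named here, the single measured step, a number 5 percentage points lower from compound 1 to compound 2 (within the scatter), falls within the scatter. Compound 3 `COc1cc(C(=O)/C=C/c2cc(-c3cc(OC)c(OC)c(OC)c3)n[nH]2)cc(OC)c1OC` differs from compound 1 by methoxy in place of hydrogen on an aromatic carbon, a change of the same kind as that step but run the other way. Because the step of a number 5 percentage points lower from compound 1 to compound 2 (within the scatter) stayed within the scatter, compound 3 is expected to give 72%, between 57% and 87%. The expected step of no change at the digits printed from compound 1 to compound 3 (within the scatter) is estimated to stay within the scatter as well.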

Compound 3, a percentage reported as activity, at one concentration (the size of the read-out at that concentration, not a potency): 65%
The estimate for compound 3 lay 7 percentage points above the measured number; the range from low to high includes it.
By their numbers in this assay, from the lowest: compounds 3, 2 and 1 (each within the scatter of the next).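

Methoxy in place of hydrogen at this position, ortho to a methoxy group and meta to a large group, gives in this assay a number 7 percentage points lower from compound 1 to compound 3 (within the scatter) for this change. Taking a methoxy group away had also stayed within the scatter, in a number 5 percentage points lower from compound 1 to compound 2 (within the scatter) at another position. So neither the removal nor the addition of a methoxy group separates these compounds at the concentration tested.

On these data alone, whether an amine, a hydroxyl or a carboxylic acid at this position would move the number beyond the scatter remains open. Nothing available explains the result.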